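Flipping One Stereocentre on a Ring Amino Acid

The compounds below may be only part of what the source reports. "The series", "measured", "known", "first", "only" and "open" are said of these compounds alone.

Compound 1, `O=C(O)[C@H]1NCC=C[C@@H]1O`, gives 25% in an assay for inhibition of alpha-N-acetylgalactosaminidase (Gallus gallus), tested at 1000 uM; a lower number here means less inhibition, a higher number more inhibition at the concentration tested (going by the name of the read-out).
Compound 2, `O=C(O)[C@@H]1NC[C@H](O)[C@@H](O)[C@@H]1O`, gives 3.4% in this assay.
Compound 3, `O=C(O)[C@@H]1NC[C@H](O)[C@@H](O)[C@H]1O`, gives 4% in this assay.

Of the three measured numbers, compound 1 stands highest, and both compound 2 and compound 3 lie beyond the usual scatter below it. Compound 4, `O=C(O)[C@@H]1NCC=C[C@@H]1O`, has not yet been measured. It keeps every atom and bond of compound 1 and changes only one point of configuration: the two compounds have the same atoms and bonds and differ only in configuration as drawn: 1 of 2 stereo elements differ; a stereocentre at a saturated ring carbon is drawn S in compound 1 and R in compound 4.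

Among the compounds with values here, one measured step bears on such a change. Between compound 2 and compound 3 the move was a number 0.6 percentage points higher from compound 2 to compound 3 (within the scatter), and because of the fact that compounds 2 and 3 differ only in the configuration as drawn, that step shows what a single flip of configuration at a ring carbon did in this series: nothing beyond the scatter. On that basis the step expected from compound 1 to compound 4 in this assay is a number 3 percentage points lower from compound 1 to compound 4 (within the scatter), that is, no clear change in either direction. For compound 4 the estimated value is 22%, expected to fall between 5% and 40%.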

Compound 4, a percentage reported as inhibition, at one concentration (the size of the read-out at that concentration, not a potency): 1.3%
For compound 4 the middle estimate is 20.7 percentage points above the measured one; the whole stated range lies above it.
By their numbers in this assay, from the lowest: compounds 4, 2 and 3 (each within the scatter of the next); then compound 1.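

A single flip of configuration at a saturated ring carbon can matter in this series, which the earlier pair did not show: a number 0.6 percentage points higher from compound 2 to compound 3 (within the scatter). In this assay, the flip in the core of compound 1 gives a clear loss, a number 23.7 percentage points lower from compound 1 to compound 4 (beyond the scatter). That loss can be put down to configuration alone, because nothing else separates the two compounds: the fact that compounds 1 and 4 differ only in the configuration as drawn

Still open, going by these compounds, is whether the other stereocentre of compound 1 matters as much, and whether the S configuration keeps its advantage when the carboxylic acid gives way to a methyl ester or an amide. These numbers also come from one concentration, so they show the size of the inhibition at that concentration and not a potency.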